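A Single Chlorine Moved Along the Sulfonyl Phenyl Ring

This account rests on a few compounds, and the source may have more. Where it says the series, first, only, none or still open, it means among the compounds named here.

Measured compounds:
compound 1 `O=S(=O)(c1c(Cl)cccc1Cl)N1CCOc2c(N3CCNCC3)cccc21` gives 0.0631 nM in an assay on HEK293 cells for displacement of a labelled ligand from 5-hydroxytryptamine receptor 6 (Homo sapiens); a lower number here means a stronger inhibitor, a higher number a weaker inhibitor
compound 2 `O=S(=O)(c1ccccc1)N1CCOc2c(N3CCNCC3)cccc21` gives 12.6 nM
compound 3 `O=S(=O)(c1ccccc1Cl)N1CCOc2c(N3CCNCC3)cccc21` gives 3.16 nM

Compound 2 stands at the highest number of the three in this assay; compound 3 is the nearest, a 4.0-fold lower number from compound 2 to compound 3 (0.60 log units; beyond the scatter), while compound 1 is furthest, seen in the step of a 200-fold higher number from compound 1 to compound 2 (2.30 log units; beyond the scatter). Compound 4 `O=S(=O)(c1cccc(Cl)c1)N1CCOc2c(N3CCNCC3)cccc21` differs from compound 2 by chloro in place of hydrogen on an aromatic carbon. Within the data shown here, the one measured step of the same kind, a 4.0-fold lower number from compound 2 to compound 3 (0.60 log units; beyond the scatter), placed the chlorine at a different carbon, so it bears on compound 4 only indirectly; no measured compound carries a chlorine meta to a large group. A modest lowering is therefore expected, probably smaller than that seen for compound 3. Compound 4 is estimated at 6.3 nM, with a range of 2 nM to 20 nM, a step of a 2.0-fold lower number from compound 2 to compound 4 (0.30 log units; within the scatter).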

Compound 4, inhibition constant: 2 nM
Compound 4: middle estimate off by 3.2-fold (0.50 log units), on the high side, and the stated range covers the measured number.
By their numbers in this assay, from the lowest: compound 1; then compounds 4 and 3 (each within the scatter of the next); then compound 2.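

Among these compounds, a chlorine meta to a large group also lowers the number, with a 6.3-fold lower number from compound 2 to compound 4 (0.80 log units; beyond the scatter), and this placement cannot be told apart from the one in compound 3, at a 1.6-fold lower number from compound 3 to compound 4 (0.20 log units; within the scatter). One chlorine here still leaves a wide gap to the two chlorines of compound 1, seen in a 32-fold higher number from compound 1 to compound 4 (1.50 log units; beyond the scatter). The worth of a chlorine is not a fixed amount but depends on the ring that carries it: the same change on two cores in this assay, a 50-fold higher number (1.70 log units; beyond the scatter) from compound 1 to compound 3 and a 6.3-fold higher number (0.80 log units; beyond the scatter) from compound 4 to compound 2, 7.9-fold (0.90 log units) apart, beyond the scatter of two such steps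

On these data alone, whether a methoxy group or an amine at this carbon would lower the number as chlorine does remains open.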